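Aspirin prodrug carbonates: stability before the next measurement

A few compounds are considered here, and "the series" means these few. Any claim that something is new, unique, unknown or untested is made for them only; others in the source may bear on it.

Measured so far:
compound 1, `CC(=O)Oc1ccccc1C(=O)OCOC(=O)OCCOc1ccc(-c2cc(=S)ss2)cc1`, 96%
compound 2, `CC(=O)Oc1ccccc1C(=O)OCOC(=O)Oc1ccc(CCCO[N+](=O)[O-])cc1`, 98%
compound 3, `CC(=O)Oc1ccccc1C(=O)OCOC(=O)OCCCO[N+](=O)[O-]`, 98%

Three compounds share one core and have been run in a physicochemical assay, read by HPLC, in phosphate buffer, with a stated time of 3 h, at pH 7.4; on this read-out lower numbers stand for a less stable compound and higher numbers for a more stable compound. Compound 1, carrying a dithiolethione-bearing aryl ether chain, gives 96%. Compound 2, whose carbonate sits on a phenol that carries a 3-(nitrooxy)propyl chain, gives 98%. Compound 3, with a 3-(nitrooxy)propyl carbonate, gives 98%. All three numbers fall within the usual scatter of one another; compound 2 and compound 3 are level at the digits shown, and compound 1 lies within the scatter of both. Nothing separates the three in this assay.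

Compound 4, `CC(=O)Oc1ccccc1C(=O)OCOC(=O)Oc1ccc(CC(CO[N+](=O)[O-])O[N+](=O)[O-])cc1`, is not yet measured. It differs from compound 2 by nitrooxy in place of hydrogen on a saturated chain carbon bound to two saturated chain carbons. Among the compounds with values here, no step between measured compounds tests this change. Since compound 2 sits at 98% and compound 3 at 98%, no movement beyond the scatter is expected in this assay; compound 4 is expected to give 97%, between 90% and 100%. The expected step is a number 1 percentage points lower from compound 2 to compound 4 (within the scatter).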

Compound 4, percent of the compound remaining: 95%
The estimate for compound 4 lay 2 percentage points above the measured number, within the range that was stated.
By their numbers in this assay, from the lowest: compounds 4, 1, 2 and 3 (each within the scatter of the next).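

Within the data shown here, the change from 3-(nitrooxy)propyl to 2,3-bis(nitrooxy)propyl is the first direct test of nitrooxy in place of hydrogen on a saturated chain carbon bound to two saturated chain carbons, and in this assay the step reads a number 3 percentage points lower from compound 2 to compound 4 (within the scatter) and so does not separate the pair. At this position, then, a group of 4 heavy atoms can enter the chain of compound 2 without a change beyond the scatter in this read-out. Nothing available bears on the reasons for this result.

The compounds shown leave open whether an amine or a carboxylic acid at this same place would read alike, or whether a longer chain would. They also leave open how the same change would read on the chain of compound 3.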